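The compounds below may be only part of what the source reports. "The series", "measured", "known", "first", "only" and "open" are said of these compounds alone.

Of the compounds shown here, three that share one core have been measured in a physicochemical assay for lipophilicity, at pH 7.4; a lower number here means a more polar compound, a higher number a more lipophilic compound. Compound 1, `Clc1ccc(NC2=NCCC3(CCCCC3)S2)cc1`, gives 1.34 in this assay. Compound 2, `CC(=O)c1cccc(NC2=NCCC3(CCCCC3)S2)c1`, gives 1.31 in this assay. Compound 3, `O=C(NC1=NCCC2(CCCCC2)S1)c1ccccc1`, gives 1.51 in this assay. Among these three numbers compound 1 stands second highest, yet its gap to compound 2 and its gap to compound 3 both lie within the usual scatter of the measurement, so the three compounds cannot be set in order against one another on this evidence.

Compound 4, `Cc1ccc(NC2=NCCC3(CCCCC3)S2)cc1`, has not yet been measured in this assay. It differs from compound 1 in a single place: methyl in place of chloro on an aromatic carbon. Among the compounds with values here, no pair of measured compounds differing only in this way is available, so no measured step can guide the expectation. The change is expected to lower the distribution coefficient only slightly, by a step, a number 0.14 log units lower from compound 1 to compound 4 (within the scatter), that is estimated to fall within the usual scatter rather than beyond it. Compound 4 is therefore expected to give about 1.2 in this assay, with an estimated range from 0.9 to 1.5.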

Compound 4, distribution coefficient: 1.48
Compound 4: middle estimate off by 0.28 log units, on the low side; the range from low to high includes it.
By their numbers in this assay, from the lowest: compounds 2, 1, 4 and 3 (each within the scatter of the next).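

Within the data shown here, the pair of compound 1 and compound 4 is the first in this set to differ in only one place, and so it gives the first measured step: in this assay methyl in place of chloro, on an aromatic carbon para to a large group, gives a number 0.14 log units higher from compound 1 to compound 4 (within the scatter) and so cannot be told apart from repeat measurement. At this position, then, the two groups cannot be distinguished by this read-out, and no direction can be claimed for the exchange, though this rests on a single pair. Nothing available here bears on why the two groups read alike.

The compounds shown leave open whether a different group at this position, such as an amine, a carboxylic acid or a longer chain, would give a step beyond the scatter. They also leave open whether methyl in place of chloro would read the same way at another place on the aromatic ring or on a different core.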